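Iodo removal on the phenol ring of compound 1

This account rests on a few compounds, and the source may have more. Where it says the series, first, only, none or still open, it means among the compounds named here.

Measured so far:
compound 1 `CCCCCCCC(=O)Nc1nnc(-c2cc(I)c(O)c(OC)c2)s1` — 0.33 nM
compound 2 `CCCCCC(=O)Nc1nnc(-c2cc(I)c(O)c(OC)c2)s1` — 1.47 nM

Compound 1 holds the lowest number of the two in an in vitro assay on HEK-293T cells for antagonist activity at transient receptor potential cation channel subfamily V member 1 (Rattus norvegicus), read by fluorescence and calcium flux, with a stated time of 30 min; a higher number here means a weaker inhibitor, a lower number a stronger inhibitor; its nearest neighbour is compound 2, and the step of a 4.5-fold higher number from compound 1 to compound 2 (0.65 log units; beyond the scatter) lies beyond the scatter. That step concerns only the acyl chain on the shared core and leaves the aromatic ring untouched.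

Compound 3 `CCCCCCCC(=O)Nc1nnc(-c2ccc(O)c(OC)c2)s1` has not yet been measured in this assay. Its difference from compound 1 is hydrogen in place of iodo on an aromatic carbon. Going by the values given here, no measured step touches the iodo group or any other substituent of the six-membered ring, so the only step in hand, the chain shortening from compound 1 to compound 2, gives no direct guide to the size or direction of this change. The expectation therefore rests on little more than the standing of compound 1 and must carry a wide range.

For compound 3 the estimate is 15 nM (range 1 nM to 200 nM), an expected step of a 45-fold higher number from compound 1 to compound 3 (1.66 log units; beyond the scatter) toward a weaker inhibitor, with the uncertainty spanning from no change beyond the scatter to a substantial loss.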

Compound 3, half-maximal inhibitory concentration: 0.15 nM
The estimate for compound 3 lay 100-fold (2.00 log units) above the measured number, outside the stated range (below it).
By their numbers in this assay, from the lowest: compound 3; then compound 1; then compound 2.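

In this assay hydrogen in place of iodo on this aromatic carbon, ortho to a hydroxy group, gives a 2.2-fold lower number from compound 1 to compound 3 (0.34 log units; beyond the scatter) and the step lies beyond the scatter, so a low number in this series does not depend on the iodo group. Compound 1 and compound 2 both carry iodo and differ only in the acyl chain, so they could say nothing about this position; with the acyl chain of compound 1 held fixed, the carbon bearing hydrogen now gives the lower number of the pair, though the change is modest. The data offer no measurement that explains the direction of this step.

The compounds shown leave open whether hydrogen in place of iodo gives a step of the same direction and size on the shorter acyl chain of compound 2. Also open, going by these compounds, is how fluoro, chloro, bromo or methyl on this aromatic carbon would compare with hydrogen and iodo, and whether a longer acyl chain would lower the number further.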